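Enlarging the Azole Substituent of Compound 2

The source may report more compounds than this note shows. Statements on the series, on what has been measured and on what is new or still open speak of the compounds shown alone.

Among the compounds with values here, compound 2 `CCCC(Oc1ccc(-n2cccn2)cc1)c1ccc(C(=O)NCCC(=O)O)cc1` gives 4100 nM in an assay on cells for displacement of a labelled ligand from Glucagon receptor (Homo sapiens), in the presence of a further agent that is not named here (on this read-out higher numbers stand for weaker inhibition and lower numbers for stronger inhibition), the highest of the three numbers measured so far. Compound 3 `CCCC(Oc1cnc(-n2cc(C(F)(F)F)cn2)nc1)c1ccc(C(=O)NCCC(=O)O)cc1` gives 1100 nM and compound 1 `CCCC(Oc1ccc(-n2cc(C(F)(F)F)cn2)c(C)c1)c1ccc(C(=O)NCCC(=O)O)cc1` gives 200 nM in this assay; each differs from compound 2 in more than one place, so neither pair forms a single step, and only the values themselves can be compared. Compound 4 `CCCC(Oc1ccc(-n2cc3c(n2)CCCC3)cc1)c1ccc(C(=O)NCCC(=O)O)cc1` has not yet been measured. Its change from compound 2 is a group of 9 heavy atoms (7 carbon, 2 nitrogen; one five-membered aromatic ring with 2 hetero atoms, one six-membered non-aromatic ring of carbon only) in place of a group of 5 heavy atoms (3 carbon, 2 nitrogen; one five-membered aromatic ring with 2 hetero atoms), on an aromatic carbon. Within the data shown here, no step between measured compounds isolates this change. Compound 4 is nonetheless expected to move toward stronger inhibition, with a step of a 4.6-fold lower number from compound 2 to compound 4 (0.66 log units; beyond the scatter) in this assay. For compound 4 the estimate is 900 nM, with a range of 250 nM to 3000 nM.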

Compound 4, inhibition constant: 690 nM
Compound 4: the middle estimate sits 1.3-fold (0.12 log units) above what was measured; low and high end bracket the measured number.
By their numbers in this assay, from the lowest: compound 1; then compounds 4 and 3 (each within the scatter of the next); then compound 2.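

At this position, on an aromatic carbon para to a large group, the azole substituent can be enlarged without loss: in this assay, adding the six-membered non-aromatic ring of carbon only to the five-membered aromatic ring gives a 5.9-fold lower number from compound 2 to compound 4 (0.77 log units; beyond the scatter). Within the data shown here, this is the first single change that can be read here, and it adds no hydrogen-bond donors or acceptors. Nothing available explains this step.

As far as these compounds go, it remains open whether a fused ring carrying an oxygen atom, or an amine on the azole, would behave alike. From the compounds shown here alone, whether the step carries over to the cores of compound 1 and compound 3 is also open.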